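A few compounds are considered here, and "the series" means these few. Any claim that something is new, unique, unknown or untested is made for them only; others in the source may bear on it.

Compound 1, `CS(=O)(=O)c1ccc(C(=O)NCC(=O)N(Cc2ccccc2)Cc2ccccc2)cc1[N+](=O)[O-]`, was tested in an assay on isolated protein for inhibition of vitamin D3 receptor (Homo sapiens), read by fluorescence polarization; on this read-out higher numbers stand for weaker inhibition and lower numbers for stronger inhibition. In this assay compound 1 gives only a limit, > 60000 nM, and not a number. Compound 2, `Cc1ccc(N2CCN(C(=O)C3CCN(C(=O)c4ccc(S(C)(=O)=O)c([N+](=O)[O-])c4)CC3)CC2)cc1`, returns the same kind of result in this assay, a limit of > 60000 nM. Compound 3, `CN(Cc1cccc(F)c1)C(=O)CCCNC(=O)c1ccc(S(C)(=O)=O)c([N+](=O)[O-])c1`, likewise yields only a limit in this assay, > 60000 nM. So compound 1 does not stand apart from the other two at all: every value recorded so far sits at one point, namely (the limit of > 60000 nM in this assay, at which 3 of the 3 values shown sit). Among the compounds with values here, no step between measured compounds can be computed from such data, since none of the three has a number to step from or to.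

Compound 4, `CN(Cc1ccccc1)C(=O)CNC(=O)c1ccc(S(C)(=O)=O)c([N+](=O)[O-])c1`, has not yet been measured in this assay. It differs from compound 1 by hydrogen in place of phenyl on a saturated chain carbon bound to an amide-type nitrogen; seen one bond further out, benzyl gives way to methyl. With compound 1 sitting at the limit, the step from compound 1 to compound 4 is expected to show no shift beyond the scatter, and in particular nothing strong enough to bring the value under the limit. Compound 4 is therefore expected to read about 90000 nM in this assay, within a range of 30000 nM to 300000 nM, which is to say it is expected to come back as a limit again, the step that the limit leaves unreadable from compound 1 to compound 4 being essentially flat.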

Compound 4, half-maximal inhibitory concentration: > 60000 nM
Compound 4 gave a limit, no number; the forecaster's own chance of this, stated with the estimate: 85%; the middle value is on the limit's open side.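

Within the data shown here, compound 4 gives only a limit in this assay, as compound 1 does, so no step between compound 1 and compound 4 can be read, and the change from benzyl to methyl has no readable size. The compounds shown leave open whether any change to the shared core would give a number instead of a limit: the limit of > 60000 nM in this assay, at which 4 of the 4 values shown sit.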